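A One-Carbon Chain Extension Tested for Cytotoxicity

This account rests on a few compounds, and the source may have more. Where it says the series, first, only, none or still open, it means among the compounds named here.

Compound 1, `CCCCCCCNc1nccnc1C(=O)NCc1ccccc1`: 100000 nM
Compound 2, `CCCCNc1cncc(C(=O)NCc2ccccc2)n1`: 100000 nM

Two compounds of this series have been examined in an ADME assay on MDCK cells (Canis lupus familiaris) for cytotoxicity, read by microscopy, with a stated time of 6 days; on this read-out lower numbers stand for higher toxicity in this test and higher numbers for lower toxicity in this test. In this assay compound 1 gives 100000 nM. In this assay compound 2 gives 100000 nM. On the numbers shown, compound 2 stands level with compound 1; the two values agree at the digits recorded, and the difference lies within the scatter of repeated measurements, so no order between them can be stated. Neither compound shows a measurable cytotoxic effect below the highest concentration reported.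

The next compound, compound 3, `CCCCCNc1cncc(C(=O)NCc2ccccc2)n1`, has not yet been measured in this assay. Compared with compound 2 the change is methyl in place of hydrogen on a saturated chain carbon, four bonds along the chain from a nitrogen on an aromatic ring. The side chain on compound 2 thus grows by a single carbon, with no ring, donor or acceptor added.

With compound 1 and compound 2 sitting at the same level despite their different chains, the step of no change at the digits printed from compound 2 to compound 3 (within the scatter) is expected to be none beyond the scatter. Compound 3 is therefore estimated at 100000 nM in this assay, within a range from 50000 nM to 100000 nM.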

Compound 3, minimum cytotoxic concentration: 20000 nM
Compound 3: middle estimate off by 5.0-fold (0.70 log units), on the high side; measured number below the stated range.
By their numbers in this assay, from the lowest: compound 3; then compounds 1 and 2 (each within the scatter of the next).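

In this assay, methyl in place of hydrogen on a saturated chain carbon, four bonds along the chain from a nitrogen on an aromatic ring, gives a 5.0-fold lower number from compound 2 to compound 3 (0.70 log units; beyond the scatter) and so moves the read-out toward higher toxicity in this test, which the equal values of compound 1 and compound 2 gave no hint of. The step is modest but lies beyond the scatter, and it comes from a change that adds one carbon and no ring, hydrogen-bond donor or hydrogen-bond acceptor, so this position on the chain is not silent in this test. No measurement at hand bears on what lies behind the step.

On these data alone, a single step fixes no trend with chain length, and whether a longer chain, such as hexyl, on the same core would lower the number further or leave it where it stands remains open. Also open, as far as these compounds go, is whether an amine or a carboxylic acid at the end of the chain would keep the number of compound 3 or bring it back toward that of compound 2.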